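The source may hold more compounds than are shown below. What is called first, only, known or untested is meant among the compounds shown, and "the series" means these compounds.

Compound 1 `c1ccc2c(-c3cn4ccnc4c(-c4ccc5ncn(C6CCCCC6)c5c4)n3)cccc2c1` is the starting point of this step. In a functional assay on NCI-H522 cells (Homo sapiens) for inhibition, read by sulforhodamine B assay, with a stated time of 48 h, tested at 10 uM (on this read-out higher numbers stand for more inhibition at the one concentration tested (going by the name of the read-out) and lower numbers for less inhibition), compound 1 gives 19.3%, the highest of the three numbers shown, although its gaps to the other two compounds both fall within the scatter. Compound 2 `c1cn2cc(-c3ccsc3)nc(-c3ccc4ncn(C5CCCCC5)c4c3)c2n1` gives 10.3% in this assay, and compound 3 `CC(=O)c1ccc(-c2cn3ccnc3c(-c3ccc4ncn(C5CCCCC5)c4c3)n2)cc1` gives 10.4%. The change to thiophen-3-yl was a number 9 percentage points lower from compound 1 to compound 2 (within the scatter), the change to 4-acetylphenyl was a number 8.9 percentage points lower from compound 1 to compound 3 (within the scatter), and the remaining pair shows a number 0.1 percentage points higher from compound 2 to compound 3 (within the scatter). Compound 4 `c1csc(-c2cn3ccnc3c(-c3ccc4ncn(C5CCCCC5)c4c3)n2)c1` has not yet been measured in this assay; it differs from compound 1 as follows: thiophen-2-yl in place of naphthalen-1-yl on an aromatic carbon. The closest comparison is the step to compound 2, where one five-membered aromatic ring with 1 hetero atom likewise took the place of naphthalen-1-yl, and that step stayed within the scatter. The step expected here is a number 8.3 percentage points lower from compound 1 to compound 4 (within the scatter), nothing beyond the scatter. Compound 4 is therefore estimated to give 11% in this assay, with a range from 2% to 22%.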

Compound 4, a percentage reported as inhibition, at one concentration (the size of the read-out at that concentration, not a potency): 13.2%
Beside the measured number, compound 4's estimate is 2.2 percentage points below it; measured number inside the range.
By their numbers in this assay, from the lowest: compounds 2, 3, 4 and 1 (each within the scatter of the next).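

In this assay, the change to thiophen-2-yl gives a number 6.1 percentage points lower from compound 1 to compound 4 (within the scatter), so a second five-membered aromatic ring with 1 hetero atom in place of naphthalen-1-yl also leaves the number within the scatter. The new compound adds a comparison of the two thiophene attachments, with thiophen-2-yl in place of thiophen-3-yl giving a number 2.9 percentage points higher from compound 2 to compound 4 (within the scatter) and so no separable difference, while thiophen-2-yl in place of 4-acetylphenyl gives a number 2.8 percentage points higher from compound 3 to compound 4 (within the scatter) and likewise separates nothing. No available evidence bears on why these numbers fall as they do.

As far as these compounds go, all four compounds carry an aromatic ring at this position, and every step among them stays within the scatter, so it remains open whether this position can move the number at all. An amine, a carboxylic acid or a saturated ring such as morpholine placed here might show that.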